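The source may hold more compounds than are shown below. What is called first, only, known or untested is meant among the compounds shown, and "the series" means these compounds.

Measured compounds:
Compound 1 `CC(C)(C)Oc1ccc2nc(N)sc2c1`; in a functional assay on the whole organism with Rattus norvegicus as the target (on this read-out lower numbers stand for an effect already at smaller amounts and higher numbers for an effect only at larger amounts of compound), compound 1 reaches only a limit, > 10 mg/kg.
Compound 2 `Nc1nc2ccc(CC(F)(F)F)cc2s1`; in this assay compound 2 gives 8 mg/kg.
Compound 3 `Nc1nc2ccc(OC(F)(F)C(F)F)cc2s1`; in this assay compound 3 gives 8.5 mg/kg.

Compound 3 holds the highest of the two numbers, with compound 2 within the scatter of it. The remaining value is the limit of compound 1 (the limit of > 10 mg/kg in this assay, at which 1 of the 3 values shown sits).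

Compound 4 `Nc1nc2ccc(OC(F)(F)C(F)(F)F)cc2s1` differs from compound 3 by fluoro in place of hydrogen on a saturated chain carbon bound to two fluorine atoms and a saturated chain carbon. For the measured compounds named here, no measured step carries this change: the only measured step, an at least 1.2-fold lower number from compound 1 to compound 2 (0.09 log units; that floor lies within the scatter), exchanges one side group for another and starts from a limit, so it gives no guide to an added fluorine. With no guidance, no step beyond the scatter is expected. Compound 4 is expected at 8 mg/kg, between 3.5 mg/kg and 18 mg/kg. The step of a 1.1-fold lower number from compound 3 to compound 4 (0.03 log units; within the scatter) is thus what is expected.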

Compound 4, dose for half-maximal effect: 2.5 mg/kg
The estimate for compound 4 lay 3.2-fold (0.51 log units) above the measured number, and the stated range ends above it.
By their numbers in this assay, from the lowest: compound 4; then compounds 2 and 3 (each within the scatter of the next). At a limit, above all of these: compound 1.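

Fluoro in place of hydrogen on a saturated chain carbon bound to two fluorine atoms and a saturated chain carbon gives a 3.4-fold lower number from compound 3 to compound 4 (0.53 log units; beyond the scatter) in this assay. It is the only step shown that lies beyond the scatter, so a change of one atom in this side chain, difluoromethyl to trifluoromethyl, is enough to move the number. Nothing measured here bears on the reason for this step.

From the compounds shown here alone, it remains open whether a longer chain such as heptafluoropropoxy keeps this lower number. Also open, going by these compounds, is how an amine or a carboxylic acid in this place would compare.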